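The source may report more compounds than this note shows. Statements on the series, on what has been measured and on what is new or still open speak of the compounds shown alone.

The measured compounds are:

compound 1 `CCc1c(F)c(N)c2c(=O)cc(-c3ccc(N)c(F)c3)oc2c1F`, which in a functional assay on MCF7 cells (Homo sapiens) for cytotoxicity, read by neutral red uptake, with a stated time of 3 days (on this read-out higher numbers stand for weaker inhibition and lower numbers for stronger inhibition), gives 130 nM
compound 2 `COc1c(F)c(N)c2c(=O)cc(-c3ccc(N)c(F)c3)oc2c1F`, which in this assay gives 100 nM
compound 3 `CN(C)c1c(F)c(N)c2c(=O)cc(-c3ccc(N)c(F)c3)oc2c1F`, which in this assay gives 39 nM

Compound 3 stands lowest of the three numbers; the nearest is the step of a 2.6-fold lower number from compound 2 to compound 3 (0.41 log units; beyond the scatter), the furthest the step of a 3.3-fold lower number from compound 1 to compound 3 (0.52 log units; beyond the scatter). The step of a 1.3-fold lower number from compound 1 to compound 2 (0.11 log units; within the scatter) separates the other two.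

Compound 4 `CN(C)CCCC(=O)OCc1c(F)c(N)c2c(=O)cc(-c3ccc(N)c(F)c3)oc2c1F` differs from compound 3 by (((3-(dimethylamino)propyl)carbonyl)oxy)methyl in place of dimethylamino on an aromatic carbon. The two steps that touch this position both end at compound 3, and both replaced a smaller group there by dimethylamino with a modest lowering of the number. Among the compounds with values here, no measured step exchanges dimethylamino for a larger chain at this carbon, so the size and direction of the new step rest on weak ground. Since the entering group still carries dimethylamino at its far end, a step of modest size at most is expected in this assay for compound 4, more likely toward a higher number than a lower one, a 2.1-fold higher number from compound 3 to compound 4 (0.31 log units; beyond the scatter). Compound 4 is therefore estimated at 80 nM, within a range from 25 nM to 300 nM.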

Compound 4, half-maximal inhibitory concentration: 29 nM
The estimate for compound 4 lay 2.8-fold (0.44 log units) above the measured number; measured number inside the range.
By their numbers in this assay, from the lowest: compounds 4 and 3 (each within the scatter of the next); then compounds 2 and 1 (each within the scatter of the next).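

In this assay, the position takes a far larger group without a clear change: a 1.3-fold lower number from compound 3 to compound 4 (0.13 log units; within the scatter), so (((3-(dimethylamino)propyl)carbonyl)oxy)methyl reads the same as dimethylamino within the scatter. The earlier compounds had shown only small groups here, and the long chain now joins dimethylamino in standing clear of the other two: a 3.4-fold lower number from compound 2 to compound 4 (0.54 log units; beyond the scatter) and a 4.5-fold lower number from compound 1 to compound 4 (0.65 log units; beyond the scatter) both lie beyond the scatter. Nothing available explains why this chain is met so well at this aromatic carbon.

As far as these compounds go, how a hydroxymethyl group, or a chain ending in a carboxylic acid or a morpholine in place of dimethylamino, would read at this carbon stays open. From the compounds shown here alone, whether a shorter or longer chain between the carbonyl and the dimethylamino would shift the number is equally open.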